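The compounds below may be only part of what the source reports. "The series", "measured", "known", "first", "only" and "open" are said of these compounds alone.

For the measured compounds named here, compound 3 `COc1cc(/C=C/C(=O)OCCCCCO[N+](=O)[O-])ccc1O` is the one compound here with a number rather than a limit. In a functional assay on M4E cells (Homo sapiens) for cytotoxicity, read by resazurin assay, with a stated time of 72 h (on this read-out higher numbers stand for weaker inhibition and lower numbers for stronger inhibition), compound 3 gives 21800 nM. Compound 1 `COc1cc(/C=C/C(=O)OCCCCCO[N+](=O)[O-])ccc1OCCCCCO[N+](=O)[O-]` gives only a limit, > 50000 nM. Compound 2 `COc1cc(/C=C/C(=O)OCc2cccc(OCc3c(-c4ccccc4)no[n+]3[O-])c2)ccc1O` likewise gives only a limit, > 50000 nM. Going by the values given here, the single measured step, an at least 2.2-fold lower number from compound 1 to compound 3 (0.36 log units; beyond the scatter), can only be read as a bound because of the limit of > 50000 nM in this assay, at which 2 of the 3 values shown sit.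

Compound 4 `COc1cc(/C=C/C(=O)OCCCCCCO[N+](=O)[O-])ccc1O` differs from compound 3 by (nitrooxy)methyl in place of nitrooxy on a saturated chain carbon, five bonds along the chain from an oxygen next to a carbonyl group. Among the compounds with values here, no measured step covers a change of this kind: the one available step removes a whole chain rather than lengthening one by a single carbon. An unchanged result is therefore expected, a 1.0-fold higher number from compound 3 to compound 4 (0.00 log units; within the scatter). Compound 4 is accordingly estimated at 22000 nM, with a range from 9000 nM to 50000 nM.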

Compound 4, half-maximal inhibitory concentration: > 50000 nM
Compound 4 gave a limit, no number (the forecaster's own chance of this, stated with the estimate: 25%); middle value at least 2.2-fold (0.35 log units) from the limit.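

The earlier step removed a whole chain, whereas this one shows that a single added carbon in the chain carrying the nitrooxy group is enough to change the result in this assay, with an at least 2.2-fold higher number from compound 3 to compound 4 (0.36 log units; beyond the scatter). The full size of this step cannot be read, as compound 4 gives only a limit of the assay: the limit of > 50000 nM in this assay, at which 3 of the 4 values shown sit.

The compounds shown leave open whether a shorter chain would bring the number lower than in compound 3. They also leave open how an amine or a carboxylic acid in place of nitrooxy would read.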